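A few compounds are considered here, and "the series" means these few. Any claim that something is new, unique, unknown or untested is made for them only; others in the source may bear on it.

Working notes on a functional assay on A2780 cells (Homo sapiens) for antiproliferative activity, read by MTT assay, with a stated time of 48 h; a lower number here means a stronger inhibitor, a higher number a weaker inhibitor: the measured compounds differ only in the group on a saturated chain carbon bound to a carbonyl carbon. Compound 1 `COc1ccc(C(=O)c2ccc3c(c2)C=CC(C)(C)O3)c(NC(=O)CBr)c1`, the bromo member, gives 1870 nM. Compound 2 `COc1ccc(C(=O)c2ccc3c(c2)C=CC(C)(C)O3)c(NC(=O)CO)c1`, the hydroxy member, gives 130 nM. Compound 3 `CCNCC(=O)Nc1cc(OC)ccc1C(=O)c1ccc2c(c1)C=CC(C)(C)O2` gives 2070 nM, within the scatter of compound 1 and far higher than compound 2.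

Next is compound 4 `COc1ccc(C(=O)c2ccc3c(c2)C=CC(C)(C)O3)c(NC(=O)CN(C)C)c1`, with dimethylamino in place of ethylamino on a saturated chain carbon bound to a carbonyl carbon: dimethylamino in place of ethylamino. Going by the values given here, two steps bear on it: a 1.1-fold higher number from compound 1 to compound 3 (0.04 log units; within the scatter), within the scatter, and the large 16-fold higher number from compound 2 to compound 3 (1.20 log units; beyond the scatter). Neither compares two amino groups, so little or no change beyond the scatter is expected in this assay.

The expected step is a 1.4-fold lower number from compound 3 to compound 4 (0.14 log units; within the scatter). The estimate for compound 4 is 1500 nM, with an expected range of 450 nM to 4500 nM.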

Compound 4, half-maximal inhibitory concentration: 1020 nM
For compound 4 the middle estimate is 1.5-fold (0.17 log units) above the measured one, and the stated range covers the measured number.
By their numbers in this assay, from the lowest: compound 2; then compounds 4, 1 and 3 (each within the scatter of the next, the first and the last beyond it).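

In this assay, the two amino groups at this position can be told apart: dimethylamino in place of ethylamino gives a 2.0-fold lower number from compound 3 to compound 4 (0.31 log units; beyond the scatter), a modest step. Dimethylamino in place of hydroxy gives a 7.8-fold higher number from compound 2 to compound 4 (0.89 log units; beyond the scatter), so the hydroxy member keeps a clear lead over this amino group too. Dimethylamino in place of bromo gives a 1.8-fold lower number from compound 1 to compound 4 (0.26 log units; within the scatter), which leaves hydroxy as the only group shown that stands apart from bromo.

No measurement shown accounts for these differences. Going by these compounds, how an unsubstituted amine, a carboxylic acid or a longer chain on this carbon would compare with hydroxy stays open.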